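The source may report more compounds than this note shows. Statements on the series, on what has been measured and on what is new or still open speak of the compounds shown alone.

Compound 1 `CCOC(=O)c1ccc(Nc2ccnc(SCC(=O)c3ccc([N+](=O)[O-])cc3)n2)cc1`: 27%
Compound 2 `CC(=O)c1cccc(Nc2ccnc(SCC(=O)c3ccc(-c4ccccc4)cc3)n2)c1`: 14%
Compound 3 `CC(=O)c1ccc(Nc2ccnc(SCC(=O)c3ccc(Cl)cc3)n2)cc1`: 46%

Of the compounds shown here, three share one core and have been tested in a functional assay on NCI/ADR-RES cells (Homo sapiens) for inhibition, read by sulforhodamine B assay, with a stated time of 48 h, tested at 10 uM; on this read-out lower numbers stand for less inhibition of growth and higher numbers for more inhibition of growth at the one concentration tested. Compound 2 stands lowest of the three numbers. Compound 1 comes nearest to it, yet its value lies beyond the usual scatter above that of compound 2, and compound 3 lies furthest away, again beyond the scatter. Compounds 1 and 3 also differ from compound 2 on the aniline side of the core, so no single change separates any two of the measured compounds.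

Compound 4 `COc1ccc(C(=O)CSc2nccc(Nc3cccc(C(C)=O)c3)n2)cc1` has not yet been measured. It is built from compound 2 by one change: methoxy in place of phenyl on an aromatic carbon. Both measured compounds that carry a small group at this place, compound 1 and compound 3, sit above compound 2, so a rise in this assay is the expectation rather than a fall, though the other differences between those compounds leave its size uncertain. An upward step beyond the scatter, of moderate size, is expected as a number 16 percentage points higher from compound 2 to compound 4 (beyond the scatter). For compound 4 the estimate in this assay is 30%, with a range from 12% to 52%.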

Compound 4, percent growth inhibition at one concentration: 40%
For compound 4 the middle estimate is 10 percentage points below the measured one; measured number inside the range.
By their numbers in this assay, from the lowest: compound 2; then compound 1; then compounds 4 and 3 (each within the scatter of the next).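

The single change of methoxy in place of phenyl gives, in this assay, a number 26 percentage points higher from compound 2 to compound 4 (beyond the scatter), and this is the only step shown that isolates one place, as the earlier compounds all differed on the aniline side as well. It shows that the group on this aromatic carbon, para to a large group, matters for growth inhibition at the one concentration tested: with the rest of compound 2 held fixed, replacing a phenyl ring of 6 heavy atoms with a methoxy of 2 heavy atoms and 1 hydrogen-bond acceptor goes with more inhibition. No measurement here explains the rise, and this one step cannot tell whether the loss of the ring or the entry of the oxygen matters more.

Still open, going by these compounds, is how an amine, a hydroxyl group or a longer chain such as ethoxy would compare with methoxy and phenyl at this place. Also open, on these data alone, is whether the same change would give a similar step with the aniline side of compound 1 or compound 3.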